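The source may hold more compounds than are shown below. What is called first, only, known or untested is meant among the compounds shown, and "the series" means these compounds.

Compound 1 `CC1=CC[C@H]2[C@H](CC[C@]2(C)O)C(C)(C)[C@@H]1CC[C@H]1[C@]2(C)CC[C@H](OCc3ccccc3)C(C)(C)O[C@H]2CC[C@@]1(C)O` and compound 2 `CC1=CC[C@H]2[C@H](CC[C@]2(C)O)C(C)(C)[C@@H]1CC[C@H]1[C@]2(C)CC/C(=N/OC(=O)c3ccccc3)C(C)(C)O[C@H]2CC[C@@]1(C)O` share the same core. Among the measured compounds shown here, in a functional assay on MDA-MB-231 cells (Homo sapiens) for antiproliferative activity, read by MTT assay, with a stated time of 72 h (a higher number here means a weaker inhibitor, a lower number a stronger inhibitor), compound 1 gives 29100 nM, the higher of the two numbers so far, and compound 2 gives 27400 nM, a gap that lies within the scatter. Compound 3 `CC1=CC[C@H]2[C@H](CC[C@]2(C)O)C(C)(C)[C@@H]1CC[C@H]1[C@]2(C)CC[C@H](OC(=O)c3ccccc3[N+](=O)[O-])C(C)(C)O[C@H]2CC[C@@]1(C)O` differs from compound 1 by one change on an oxygen on a saturated carbon: (2-nitrophenyl)carbonyl in place of benzyl on an oxygen on a saturated carbon. For the measured compounds named here, no measured pair covers this change, so no step beyond the scatter is expected in this assay in either direction; the expected step is a 1.2-fold lower number from compound 1 to compound 3 (0.07 log units; within the scatter). Compound 3 is estimated at 25000 nM, with a range from 9000 nM to 70000 nM.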

Compound 3, half-maximal inhibitory concentration: 38700 nM
Compound 3: middle estimate off by 1.5-fold (0.19 log units), on the low side; the range from low to high includes it.
By their numbers in this assay, from the lowest: compounds 2, 1 and 3 (each within the scatter of the next).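

At the oxygen on a saturated carbon, (2-nitrophenyl)carbonyl in place of benzyl in this assay gives a step (a 1.3-fold higher number from compound 1 to compound 3 (0.12 log units; within the scatter)) that lies within the scatter. This position therefore accepts a group with more heavy atoms and added hydrogen-bond acceptors without a step beyond the scatter, at least in this one pair. No measured property available here bears on this result. On these data alone, whether an amine, a carboxylic acid or a longer alkyl chain at this oxygen would give a step beyond the scatter in this assay remains open.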